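A few compounds are considered here, and "the series" means these few. Any claim that something is new, unique, unknown or untested is made for them only; others in the source may bear on it.

Measured so far in a functional assay on HL-60 cells (Homo sapiens) for cytotoxicity, read by MTT assay, with a stated time of 48 h; a lower number here means a stronger inhibitor, a higher number a weaker inhibitor:
compound 1 `COc1ccccc1-c1cc(COc2ccc3oc(=O)ccc3c2)on1` gives "not determined" (no result reported) as its result
compound 2 `O=c1ccc2cc(OCc3cn(-c4ccccc4)nn3)ccc2o1` gives 41600 nM as its result

For the measured compounds named here, compound 2 holds the only number available, because compound 1 has no result, so it cannot yet be ranked against anything. Compound 3 `N#Cc1ccccc1-n1cc(COc2ccc3oc(=O)ccc3c2)nn1` keeps everything in compound 2 except one place, where phenyl becomes 2-cyanophenyl. This puts cyano in place of hydrogen on an aromatic carbon, ortho to a large group, and the count reads cyano in place of hydrogen on an aromatic carbon in full. Going by the values given here, no measured pair here shows what such a swap does in this assay, so no step beyond the usual scatter is expected, and neither direction is favoured. The expected change is a 1.0-fold lower number from compound 2 to compound 3 (0.02 log units; within the scatter) in size. Compound 3 is therefore estimated to read 40000 nM (range 14000 nM to 110000 nM).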

Compound 3, half-maximal inhibitory concentration: 52100 nM
Compound 3: the middle estimate sits 1.3-fold (0.11 log units) below what was measured; the range from low to high includes it.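

For the compounds shown here, compound 2 and compound 3 form the first measured pair that differs in one place, and in this assay the swap of hydrogen for cyano gives a small step (a 1.3-fold higher number from compound 2 to compound 3 (0.10 log units; within the scatter)). At this position, on an aromatic carbon ortho to a large group, the phenyl to 2-cyanophenyl change therefore leaves the reading within the usual scatter, so the two compounds cannot be told apart in this assay. No outside measurement bears on this result.

As far as these compounds go, it remains open whether an amine, a carboxylic acid or a longer chain at this same position would shift the number beyond the scatter. From the compounds shown here alone, it is also open how cyano would read at other places on the phenyl ring, and compound 1, with no result, adds nothing to either question.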